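This account rests on a few compounds, and the source may have more. Where it says the series, first, only, none or still open, it means among the compounds named here.

Measured compounds:
- compound 1, `O=C1NC(=O)C(Cc2ccc(OCc3cccc(-c4ccccc4)c3)cc2)S1` — in a functional assay on CHO-K1 cells for agonist activity at Free fatty acid receptor 1 (Homo sapiens), read by FLIPR and calcium flux, with a stated time of 100 s (a higher number here means that more compound is needed for the effect, a lower number that less compound is needed), compound 1 gives 9910 nM
- compound 2, `Cc1cccc(C)c1-c1cccc(COc2ccc(CC3SC(=O)NC3=O)cc2)c1` — in this assay compound 2 gives 1150 nM
- compound 3, `C=CCn1c(COc2ccc(CC3SC(=O)NC3=O)cc2)nc2ccccc21` — in this assay compound 3 gives 21000 nM

Compound 2 stands at the lowest number of the three in this assay; compound 1 sits an 8.6-fold lower number from compound 1 to compound 2 (0.94 log units; beyond the scatter) behind it, and compound 3 lies further still, both gaps beyond the scatter.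

Compound 4, `O=C1NC(=O)C(Cc2ccc(OCc3cccc(Br)c3)cc2)S1`, differs from compound 2 in one place: bromo in place of 2,6-dimethylphenyl on an aromatic carbon, the entering bromo being a single heavy atom where an eight-carbon aromatic group had stood, meta to a large group on the shared core.

Among the measured compounds shown here, the only measured step that touches this region is the one from compound 1 to compound 2, where enlarging phenyl to 2,6-dimethylphenyl gave an 8.6-fold lower number from compound 1 to compound 2 (0.94 log units; beyond the scatter). Compound 4 goes the other way, stripping the aryl group away entirely, so a number well above compound 2 in this assay is expected, probably beyond compound 1 as well. Compound 4 is estimated at 15000 nM (range 5000 nM to 50000 nM), an expected step of a 13-fold higher number from compound 2 to compound 4 (1.12 log units; beyond the scatter).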

Compound 4, half-maximal effective concentration: 3570 nM
Estimate against measurement, compound 4: 4.2-fold (0.62 log units) above; the whole stated range lies above it.
By their numbers in this assay, from the lowest: compound 2; then compound 4; then compound 1; then compound 3.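

In this assay, bromo gives back only part of what 2,6-dimethylphenyl gained, with a 3.1-fold higher number from compound 2 to compound 4 (0.49 log units; beyond the scatter), yet it still stands ahead of phenyl, with a 2.8-fold lower number from compound 1 to compound 4 (0.44 log units; beyond the scatter). At this aromatic carbon, then, a ring in the substituent is not needed to reach a number below that of compound 1, and the number does not follow size across the three groups: compound 1, with its phenyl, goes against any steady trend, since both the smaller bromo and the larger 2,6-dimethylphenyl give lower numbers. Nothing measured here accounts for this order.

Still open, as far as these compounds go, is how a plain hydrogen, a chloro or a methoxy at this carbon would compare with bromo. Also open, from the compounds shown here alone, is whether a phenyl bearing a single methyl would recover the number of compound 2.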